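Adding a side chain to the amine nitrogen

A few compounds are considered here, and "the series" means these few. Any claim that something is new, unique, unknown or untested is made for them only; others in the source may bear on it.

Measured in a physicochemical assay for solubility, read by HPLC, at pH 2; on this read-out lower numbers stand for lower solubility and higher numbers for higher solubility:
Compound 1 `OC1CC2(CCNCC2)Oc2c1ccc1ccccc21`: 40000 nM
Compound 2 `c1ccc2c3c(ccc2c1)CCC1(CCNCC1)O3`: 40000 nM

Among the compounds with values here, only two compounds have been measured in this assay, so the evidence here is thin. Level with compound 1, compound 2 reads 40000 nM. Within the data shown here, the one measured step, no change at the digits printed from compound 1 to compound 2 (within the scatter), replaces hydroxy with hydrogen on a saturated ring carbon.

The next compound changes a different place. Compound 3 `c1ccc2c3c(ccc2c1)CCC1(CCN(CCC2CCCCC2)CC1)O3` carries 2-cyclohexylethyl in place of hydrogen on an amine nitrogen in a ring. Among the measured compounds shown here, no measured step involves this nitrogen, and none adds a group of this size. The flat result of no change at the digits printed from compound 1 to compound 2 (within the scatter) therefore bears on the new change only weakly, and it cannot be carried over as a forecast of no change.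

The expectation rests on judgement more than on measured precedent, and it points downward, with a wide margin. The expected step is a fall beyond the scatter, a 2.7-fold lower number from compound 2 to compound 3 (0.43 log units; beyond the scatter). For compound 3 the estimated value is 15000 nM, with an expected range from 3000 nM to 40000 nM.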

Compound 3, solubility: 40000 nM
Compound 3: the middle estimate sits 2.7-fold (0.43 log units) below what was measured; the measured number falls inside the stated range.
By their numbers in this assay, from the lowest: compounds 1, 2 and 3 (each within the scatter of the next).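

Placing 2-cyclohexylethyl, a group of 8 heavy atoms with one six-membered non-aromatic ring of carbon only, on the amine nitrogen in a ring gives the first reading at this position in this assay, and the step is no change at the digits printed from compound 2 to compound 3 (within the scatter). This position therefore accepts a large all-carbon side chain with no difference in this read-out beyond the scatter, which the earlier step, no change at the digits printed from compound 1 to compound 2 (within the scatter), made at a saturated ring carbon, could not show. The compounds shown offer no measurement that could account for this flat reading.

Still open, from the compounds shown here alone, is whether this holds for 2-cyclohexylethyl alone or for other groups on the same nitrogen, such as a shorter chain, a benzyl group or a chain ending in a carboxylic acid or a second amine. Also open is whether 2-cyclohexylethyl on this nitrogen would give the same reading with the hydroxy group of compound 1 in place, since the two changes appear together in none of the compounds shown.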